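Cytotoxicity notes on three diaryl ethers and one analogue

The source may hold more compounds than are shown below. What is called first, only, known or untested is meant among the compounds shown, and "the series" means these compounds.

Measured so far in an ADME assay on H9 cells (Homo sapiens) for cytotoxicity, read by XTT assay, with a stated time of 6 days; a lower number here means that less compound is tolerated, a higher number that more compound is tolerated:
compound 1, `Cc1cc(C=O)cc(C)c1Oc1ccc([N+](=O)[O-])c(Nc2ccc(C#N)cc2)c1`, gives 14200 nM.
compound 2, `Cc1cc(Br)cc(C)c1Oc1ccc([N+](=O)[O-])c(Nc2ccc(C#N)cc2)c1`, gives only a limit, > 57000 nM.
compound 3, `Cc1cc(Br)cc(C)c1Oc1cc(Nc2ccc(C#N)cc2)c([N+](=O)[O-])cc1[N+](=O)[O-]`, gives only a limit, > 51700 nM.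

Compound 2 and compound 1 differ by formyl in place of bromo on an aromatic carbon; this gives an at least 4.0-fold lower number from compound 2 to compound 1 (0.60 log units; beyond the scatter). The limit for compound 2 is the limit of > 57000 nM in this assay, at which 1 of the 3 values shown sits. The cores of compound 2 and compound 3 differ by nitro in place of hydrogen on an aromatic carbon; the step that the two limits leave unreadable from compound 2 to compound 3 cannot be sized, since compound 3 sits at the limit of > 51700 nM in this assay, at which 1 of the 3 values shown sits. Compound 4, `Cc1cc(C=O)cc(C)c1Oc1cc(Nc2ccc(C#N)cc2)c([N+](=O)[O-])cc1[N+](=O)[O-]`, is not yet measured; it differs from compound 3 by formyl in place of bromo on an aromatic carbon, the same change as between compound 2 and compound 1. Because an at least 4.0-fold lower number from compound 2 to compound 1 (0.60 log units; beyond the scatter) lies beyond the scatter, a step in the same direction is expected, an at least 3.6-fold lower number from compound 3 to compound 4 (0.56 log units; beyond the scatter), though the limit on compound 3 leaves its size open. Compound 4 is estimated at 14000 nM in this assay, between 5000 nM and 50000 nM.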

Compound 4, half-maximal cytotoxic concentration: 57900 nM
Compound 4: middle estimate off by 4.1-fold (0.62 log units), on the low side; measured number above the stated range.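

On the core of compound 1, formyl in place of bromo gave an at least 4.0-fold lower number from compound 2 to compound 1 (0.60 log units; beyond the scatter), but on the core of compound 3 the same change cannot be sized, and neither step that ends or starts at compound 3 can be read. Compound 3 stands only at a limit: the limit of > 51700 nM in this assay, at which 1 of the 4 values shown sits. The nitro step on the formyl compounds gives a 4.1-fold higher number from compound 1 to compound 4 (0.61 log units; beyond the scatter), so the low number of compound 1 does not recur in compound 4, but this does not show whether formyl lowers, raises or leaves unchanged the number on the core of compound 3.

Open, from the compounds shown here alone, is how an amine or a carboxylic acid in place of formyl would read in this assay. Also open, going by these compounds, is whether the nitro step has any size on the bromo compounds.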